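The source may hold more compounds than are shown below. What is called first, only, known or untested is meant among the compounds shown, and "the series" means these compounds.

Going by the values given here, in a functional assay on MDA-MB-231 cells (Homo sapiens) for antiproliferative activity, read by MTT assay, with a stated time of 96 h (on this read-out higher numbers stand for weaker inhibition and lower numbers for stronger inhibition), compound 1 `CC(C)=CCC/C(C)=C/CC/C(C)=C/CC[C@]1(C)CCc2cc(OC(=O)NS(=O)(=O)c3ccc(C)cc3)cc(C)c2O1` gives 6600 nM, the only true number among the measured compounds. Compound 2 `CC(C)=CCC/C(C)=C/CC/C(C)=C/CC[C@]1(C)CCc2cc(OC(=O)NS(=O)(=O)c3ccc(Cl)cc3)cc(C)c2O1` reads > 10000 nM, which is a limit. Compound 3 `CC(C)=CCC/C(C)=C/CC/C(C)=C/CC[C@]1(C)CCc2cc(OC(=O)NCc3ccccc3)cc(C)c2O1` reads > 10000 nM, also a limit. Compound 4 `CC(C)=CCC/C(C)=C/CC/C(C)=C/CC[C@]1(C)CCc2cc(OC(=O)NS(=O)(=O)c3ccc(C)cc3)c(C)c(C)c2O1` differs from compound 1 at one place on the core: methyl in place of hydrogen on an aromatic carbon. Two measured steps start from compound 1, an at least 1.5-fold higher number from compound 1 to compound 2 (0.18 log units; that floor lies within the scatter) and an at least 1.5-fold higher number from compound 1 to compound 3 (0.18 log units; that floor lies within the scatter), but both changes lie elsewhere in the molecule, and neither shows a size beyond the scatter. In this assay the expected change is therefore small, a 1.2-fold lower number from compound 1 to compound 4 (0.08 log units; within the scatter), with no firm direction. The estimated value for compound 4 is 5500 nM, with an expected range of 2200 nM to 10000 nM.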

Compound 4, half-maximal inhibitory concentration: > 10000 nM
Compound 4: only a limit was reported; the forecaster's own chance of this, stated with the estimate: 25%; at least 1.8-fold (0.25 log units) between middle value and limit.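

Going by these compounds alone, the first change on the shared core, methyl in place of hydrogen on an aromatic carbon, gives in this assay an at least 1.5-fold higher number from compound 1 to compound 4 (0.18 log units; that floor lies within the scatter). This position therefore shows no gain over compound 1, though the floor alone does not establish a real loss. Compound 4 gives only a limit, and the true size of the step cannot be read because the reading stops there: the limit of > 10000 nM in this assay, at which 3 of the 4 values shown sit.

Going by these compounds, it remains open whether a fluoro, methoxy or ethyl group on this aromatic carbon would give a measurable number. On these data alone, it also remains open whether the added methyl would behave the same way with a benzyl group on the amide-type nitrogen.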